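A few compounds are considered here, and "the series" means these few. Any claim that something is new, unique, unknown or untested is made for them only; others in the source may bear on it.

Measured in a functional assay on HCT-116 cells (Homo sapiens) for inhibition, read by sulforhodamine B assay, with a stated time of 96 h; on this read-out lower numbers stand for stronger inhibition of growth and higher numbers for weaker inhibition of growth:
compound 1 (`CC[C@@H](Nc1nc(NCc2ccccn2)c2ncn(C(C)C)c2n1)C(C)(C)O`) gives > 50000 nM (a limit of the assay)
compound 2 (`CC[C@@H](Nc1nc(NCc2ccccn2)c2ncn(C(C)C)c2n1)C(C)O`) gives 18000 nM
compound 3 (`CCC(O)[C@@H](CC)Nc1nc(NCc2ccccn2)c2ncn(C(C)C)c2n1`) gives 29000 nM

The entry for compound 1 is a limit of the assay and not a number. Compound 3 stands level with compound 2, since a 1.6-fold higher number from compound 2 to compound 3 (0.21 log units; within the scatter) stays within the scatter.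

Compound 4 (`CC[C@@H](Nc1nc(NCc2ccccn2)c2ncn(C(C)C)c2n1)C(O)C(C)(C)C`) carries tert-butyl in place of ethyl on a saturated chain carbon bound to an oxygen on a saturated carbon and a saturated chain carbon.

All three measured steps change this same chain. Within the data shown here, the closest comparison is the one already given for compound 2 and compound 3, where methyl replaces hydrogen and the numbers stay within the scatter. Among the measured compounds shown here, by contrast, an at least 2.7-fold lower number from compound 1 to compound 2 (0.44 log units; beyond the scatter) is the one step beyond the scatter, with hydrogen in place of methyl. The third, an at least 1.7-fold lower number from compound 1 to compound 3 (0.23 log units; that floor lies within the scatter) has a floor within the scatter. Added carbon on this chain therefore gives no consistent answer across these few compounds.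

In this assay no step beyond the scatter is expected, with a slight lean towards higher numbers. The estimated change is a 1.1-fold higher number from compound 3 to compound 4 (0.04 log units; within the scatter) overall. Compound 4 is expected at 32000 nM with an estimated range from 14000 nM to 50000 nM in this assay.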

Compound 4, concentration for 50% growth inhibition: 29000 nM
Estimate against measurement, compound 4: 1.1-fold (0.04 log units) above; measured number inside the range.
By their numbers in this assay, from the lowest: compounds 2, 3 and 4 (each within the scatter of the next). At a limit, above all of these: compound 1.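

In this assay, tert-butyl in place of ethyl on a saturated chain carbon bound to an oxygen on a saturated carbon and a saturated chain carbon gives no change at the digits printed from compound 3 to compound 4 (within the scatter), so this place takes a group of 4 heavy atoms with no step beyond the scatter. Set against methyl at the same place, tert-butyl gives a 1.6-fold higher number from compound 2 to compound 4 (0.21 log units; within the scatter), which leaves compounds 2, 3 and 4 level as this group runs from methyl through ethyl to tert-butyl, a wider span of size than the earlier compounds covered. From the compounds shown here alone, the remaining step starts from a limit of the assay and reads an at least 1.7-fold lower number from compound 1 to compound 4 (0.23 log units; that floor lies within the scatter), and it stays open whether these two compounds differ at all because that one entry is not a number: the limit of > 50000 nM in this assay, at which 1 of the 4 values shown sits.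

Among these compounds, every group at this place so far is a plain carbon group, so it remains open whether an amine, a carboxylic acid or a phenyl ring there would move the number beyond the scatter. All four compounds also keep the hydroxyl on the chain, which leaves open what a methoxy group or a plain hydrogen in its place would do.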